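The source may hold more compounds than are shown below. What is called first, only, known or untested is meant among the compounds shown, and "the series" means these compounds.

Among the compounds with values here, in a functional assay on A375P cells (Homo sapiens) for antiproliferative activity, read by MTT assay, with a stated time of 48 h (on this read-out lower numbers stand for stronger inhibition and higher numbers for weaker inhibition), compound 2 `Nc1cccc2c(-c3cccc(NC(=O)c4ccc5c(c4)OCCO5)c3)ccnc12` gives 860 nM, the lowest of the two numbers recorded; the only other compound, compound 1 `COc1ccc(C(=O)Nc2cccc(-c3ccnc4c(N)cccc34)c2)cc1OC`, gives 9500 nM. Within the data shown here, the step of an 11-fold lower number from compound 1 to compound 2 (1.04 log units; beyond the scatter) is the single measured step, and it concerns the aryl group on the carbonyl carbon, not the ring that carries the amide nitrogen. Compound 3 `Cc1ccc(NC(=O)c2ccc3c(c2)OCCO3)cc1-c1ccnc2c(N)cccc12` differs from compound 2 by methyl in place of hydrogen on an aromatic carbon. Among the measured compounds shown here, no measured step touches this position, so the step from compound 1 to compound 2 offers no direct guide, only a reminder that changes can be large. With nothing in the data pointing either way, the expected step of a 1.0-fold higher number from compound 2 to compound 3 (0.02 log units; within the scatter) is within the scatter. Compound 3 is therefore estimated at 900 nM in this assay, with a range from 300 nM to 2700 nM that allows for a moderate shift in either direction.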

Compound 3, half-maximal inhibitory concentration: 280 nM
Compound 3: middle estimate off by 3.2-fold (0.51 log units), on the high side; measured number outside the range, below it.
By their numbers in this assay, from the lowest: compound 3; then compound 2; then compound 1.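

In this assay, the step of a 3.1-fold lower number from compound 2 to compound 3 (0.49 log units; beyond the scatter) is the first shown on the ring that carries the amide nitrogen, and it lies beyond the scatter. This position, ortho to a large group and para to a large group, therefore responds to a change as small as methyl in place of hydrogen, and the change goes toward stronger inhibition. The data offer no explanation for this gain.

The compounds shown leave open whether ethyl, methoxy, chlorine or an amine at this position would lower the number further or raise it again. They also leave open whether methyl would give a similar step with the 3,4-dimethoxyphenyl group of compound 1 on the carbonyl carbon, as its effect is shown only with the 2,3-dihydro-1,4-benzodioxin-6-yl group.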